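A few compounds are considered here, and "the series" means these few. Any claim that something is new, unique, unknown or untested is made for them only; others in the source may bear on it.

In a functional assay on HT-29 cells (Homo sapiens) for cytotoxicity, read by MTT assay, with a stated time of 72 h (on this read-out lower numbers stand for stronger inhibition and higher numbers for weaker inhibition), the measured compounds give the following numbers:

Compound 1, `Cc1ccc(/C=C2\S/C(=N\c3csc(-c4ccc(Cl)cc4)c3)NC2=O)cc1`: 6400 nM.
Compound 2, `CN(C)c1ccc(/C=C2\S/C(=N\c3csc(-c4ccc(Cl)cc4)c3)NC2=O)cc1`: 1500 nM.
Compound 3, `CN(C)c1ccc(/C=C2\S/C(=N\c3nc(-c4ccc(Cl)cc4)cs3)NC2=O)cc1`: 500 nM.

Compound 1 and compound 2 share one core and differ in a single place: methyl in place of dimethylamino on an aromatic carbon. The effect of that change is read directly from the pair, a 4.3-fold higher number from compound 2 to compound 1 (0.63 log units; beyond the scatter), so the dimethylamino-bearing compound gives the lower number. Compound 3 carries the same 4-(dimethylamino)phenyl group as compound 2 but sits on a different core; the difference between the two cores is not broken down here. In this assay compound 3 gives the lowest number of the three, and its steps to compound 2 and to compound 1 both lie beyond the usual scatter.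

Compound 4, `Cc1ccc(/C=C2\S/C(=N\c3nc(-c4ccc(Cl)cc4)cs3)NC2=O)cc1`, has not yet been measured. It stands to compound 3 as compound 1 stands to compound 2: methyl in place of dimethylamino on an aromatic carbon. The place of the change reads the same in both pairs, so this is the same change, made once on each core. Going by the values given here, only one measured example of it exists, so the expectation for compound 4 rests on that single step alone. Compound 4 is expected to give 2200 nM in this assay, with a likely range from 900 nM to 5500 nM. Among the compounds with values here, the estimated step of a 4.4-fold higher number from compound 3 to compound 4 (0.64 log units; beyond the scatter) is expected to match the earlier one in size, because the one measured instance of this change gave a 4.3-fold higher number from compound 2 to compound 1 (0.63 log units; beyond the scatter).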

Compound 4, half-maximal inhibitory concentration: 500 nM
Estimate against measurement, compound 4: 4.4-fold (0.64 log units) above; the measured number lies below the stated range.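

Replacing dimethylamino with methyl on the core shared by compound 3 and compound 4 gives no change at the digits printed from compound 3 to compound 4 (within the scatter) in this assay, so on this core the read-out does not separate the two groups. The size of this change's step therefore did not carry over from one core to the other, and the core it is made on matters in this small set: the same change on two cores in this assay, a 4.3-fold higher number (0.63 log units; beyond the scatter) from compound 2 to compound 1 and no change at the digits printed (within the scatter) from compound 3 to compound 4, 4.3-fold (0.63 log units) apart, beyond the scatter of two such steps. This shows that a step measured on one core is not a safe guide to the same change on another core here, but it rests on just two pairs of compounds, with one step on each core, and it does not show which feature of the cores lies behind the difference or whether the same would hold for any other change.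

The compounds shown leave open how other groups at the same place on the aromatic ring, such as a methoxy group, a primary amine or a carboxylic acid, would behave on each of the two cores. Whether such groups would give different steps on the two cores, as dimethylamino and methyl do, or matching ones, also stays unanswered.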